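Chloro in place of trifluoromethoxy on a six-membered ring

The compounds below may be only part of what the source reports. "The series", "measured", "known", "first", "only" and "open" are said of these compounds alone.

Compound 1, `O=C(NC1CCCC1)c1noc(-c2cccc(Cl)c2)c1Br`: 4220 nM
Compound 2, `O=C(NC1CCCC1)c1noc(-c2ccc(OC(F)(F)F)cc2)c1Br`: 1250 nM

Of the compounds shown here, two have been measured in a functional assay on CHO cells for antagonist activity at transient receptor potential cation channel subfamily V member 1 (Homo sapiens), read by fluorescence and calcium flux; a lower number here means a stronger inhibitor, a higher number a weaker inhibitor. Compound 1 gives 4220 nM and compound 2 gives 1250 nM. Compound 2 therefore stands lowest of the two numbers, and its nearest neighbour, compound 1, sits at a number higher by an amount beyond the usual scatter of this assay. For the measured compounds named here, no single-point step between measured compounds is available, so the next change can only be judged from these two values and from the structures.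

Compound 3, `O=C(NC1CCCC1)c1noc(-c2ccc(Cl)cc2)c1Br`, has not yet been tested. It differs from compound 2 in one respect: chloro in place of trifluoromethoxy on an aromatic carbon. Compound 1 also carries a chloro group on its own six-membered ring, and it is the weaker of the two measured compounds. Taking compound 2 as the starting point, compound 3 is expected to lose some potency, so the step of a 1.8-fold higher number from compound 2 to compound 3 (0.25 log units; within the scatter) is estimated to be a modest rise, possibly not much beyond the scatter. For compound 3 the estimate in this assay is 2200 nM, within a range from 800 nM to 6000 nM.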

Compound 3, half-maximal inhibitory concentration: 370 nM
For compound 3 the middle estimate is 5.9-fold (0.77 log units) above the measured one; the measured number lies below the stated range.
By their numbers in this assay, from the lowest: compound 3; then compound 2; then compound 1.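

In this assay, chloro in place of trifluoromethoxy on an aromatic carbon para to a large group gives a 3.4-fold lower number from compound 2 to compound 3 (0.53 log units; beyond the scatter) and thus a stronger inhibitor, even though a single chlorine atom replaces a group of five heavy atoms. Where the chloro sits matters as well: 4-chlorophenyl in place of 3-chlorophenyl gives an 11-fold lower number from compound 1 to compound 3 (1.06 log units; beyond the scatter), so the weak result of compound 1 cannot be read as a verdict on chloro in general. Nothing measured here explains why either change strengthens inhibition.

The compounds shown leave open whether chloro itself is special at this position, or whether fluoro, bromo, methyl or a nitrile would serve as well or better. They also leave open whether the advantage of the 4-chlorophenyl group would hold if the bromo on the shared core gave way to a hydrogen or a methyl group, and what a second chloro on the same ring would do.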